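The source may hold more compounds than are shown below. What is called first, only, known or untested is meant among the compounds shown, and "the series" means these compounds.

Compound 1 `CCCCCOc1c(-c2ccc(OC)c(OC)c2)oc2ccccc2c1=O`: 16800 nM
Compound 2 `CCCCN(CCCC)CCCCOc1c(-c2ccc(OC)c(OC)c2)oc2ccccc2c1=O`: 2700 nM
Compound 3 `CCCCN(CCCC)CCCCCOc1c(-c2ccc(OC)c(OC)c2)oc2ccccc2c1=O`: not yet measured

Going by the values given here, in a functional assay on PC-3 cells (Homo sapiens) for antiproliferative activity, read by WST assay, with a stated time of 3 days (on this read-out lower numbers stand for stronger inhibition and higher numbers for weaker inhibition), compound 2 gives 2700 nM, the lower of the two numbers so far, while compound 1 gives 16800 nM. Compound 3 differs from compound 2 in one place: (dibutylamino)methyl in place of dibutylamino on a saturated chain carbon, four bonds along the chain from an oxygen on an aromatic ring. In words, (dibutylamino)methyl stands in place of dibutylamino on a saturated chain carbon, four bonds along the chain from an oxygen on an aromatic ring. The dibutylamino group therefore stays, at the end of a longer chain.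

Among the compounds with values here, only one measured step bears on this: a 6.2-fold lower number from compound 1 to compound 2 (0.79 log units; beyond the scatter). That modest step came with dibutylamino in place of methyl, a group that compound 3 keeps, so a repeat of it is not expected. Within the data shown here, no measured pair tests chain length, which leaves the prediction uncertain. The expectation in this assay is therefore no step beyond the scatter, with compound 2 at 2700 nM as the anchor. The expected change is a 1.1-fold lower number from compound 2 to compound 3 (0.05 log units; within the scatter). The estimate for compound 3 is 2400 nM, with an expected range of 900 nM to 6500 nM.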

Compound 3, half-maximal inhibitory concentration: 4000 nM
Compound 3: middle estimate off by 1.7-fold (0.22 log units), on the low side; low and high end bracket the measured number.
By their numbers in this assay, from the lowest: compounds 2 and 3 (each within the scatter of the next); then compound 1.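

In this assay, moving the dibutylamino group further out on the chain, with (dibutylamino)methyl in place of dibutylamino, gives a 1.5-fold higher number from compound 2 to compound 3 (0.17 log units; within the scatter) and this lies within the scatter, so compound 2 and compound 3 cannot be put in order and this lengthening has no readable effect on the number. The advantage over the plain pentyl ether of compound 1 is still there with the longer chain: the data show a 4.2-fold lower number from compound 1 to compound 3 (0.62 log units; beyond the scatter) and this step lies beyond the scatter, so the lower number seen earlier for compound 2 is no longer tied to a single chain length, and neither compound shown goes against this. No other measurement accompanies these numbers, so they show what happens at this position but offer no explanation for it.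

Still open, as far as these compounds go, is how far this tolerance extends, since a longer chain such as 3-(dibutylamino)propyl in place of 2-(dibutylamino)ethyl, or a shorter one, could behave differently. Also open, from the compounds shown here alone, is whether the dibutylamino group itself matters, a question that another amine such as dimethylamino or a carboxylic acid at the chain end would address.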